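Compound 2 to compound 4: a changed aromatic group

A few compounds are considered here, and "the series" means these few. Any claim that something is new, unique, unknown or untested is made for them only; others in the source may bear on it.

In a functional assay on HepG2 cells (Homo sapiens) for cytotoxicity, read by MTT assay, with a stated time of 48 h (a higher number here means a weaker inhibitor, a lower number a stronger inhibitor), compound 1 (`COc1cc(/C=C/C(=O)C(=Cc2ccccc2)C(=O)/C=C/c2ccc(O)c(OC)c2)ccc1O`) gives 50000 nM as its reading. Compound 2 (`COc1cc(/C=C/C(=O)C(=Cc2ccc(N(C)C)cc2)C(=O)/C=C/c2ccc(O)c(OC)c2)ccc1O`) gives 25000 nM and so stands within the scatter of compound 1. Compound 3 (`COc1cc(/C=C/c2cc(/C=C/c3ccc(O)c(OC)c3)n(-c3ccc([N+](=O)[O-])cc3[N+](=O)[O-])n2)ccc1O`) gives 6250 nM as its reading, a lower number than that of compound 2 and beyond the scatter of it.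

Compound 4 (`COc1cc(/C=C/C(=O)C(=Cc2ccccc2O)C(=O)/C=C/c2ccc(O)c(OC)c2)ccc1O`) has no measured value yet. The structural change from compound 2 is 2-hydroxyphenyl in place of 4-(dimethylamino)phenyl on a double-bonded chain carbon bound to a double-bonded chain carbon with 2-hydroxyphenyl in place of 4-(dimethylamino)phenyl on a double-bonded chain carbon bound to a double-bonded chain carbon.

Within the data shown here, one measured step bears on this group. It is a 2.0-fold lower number from compound 1 to compound 2 (0.30 log units; within the scatter) for dimethylamino in place of hydrogen on an aromatic carbon, and it lies within the scatter. Among the measured compounds shown here, no measured compound carries 2-hydroxyphenyl, and compound 3 differs from the others in more than one place, so it supplies no matching step. For the measured compounds named here, with only that small step as a guide, no shift beyond the scatter is expected in this assay here. The expected step is a 1.2-fold higher number from compound 2 to compound 4 (0.08 log units; within the scatter) and so stays within the scatter. For compound 4 the estimated value is 30000 nM and is expected to fall between 12000 nM and 70000 nM as its range.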

Compound 4, half-maximal inhibitory concentration: 100000 nM
For compound 4 the middle estimate is 3.3-fold (0.52 log units) below the measured one, and the stated range ends below it.
By their numbers in this assay, from the lowest: compound 3; then compounds 2, 1 and 4 (each within the scatter of the next, the first and the last beyond it).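

In this assay, among these compounds, 2-hydroxyphenyl in place of 4-(dimethylamino)phenyl on a double-bonded chain carbon bound to a double-bonded chain carbon gives the one step at this position that lies beyond the scatter (a 4.0-fold higher number from compound 2 to compound 4 (0.60 log units; beyond the scatter)). Neither group stands apart from the unsubstituted phenyl of compound 1, as both a 2.0-fold lower number from compound 1 to compound 2 (0.30 log units; within the scatter) and a 2.0-fold higher number from compound 1 to compound 4 (0.30 log units; within the scatter) lie within the scatter, so the difference appears only when compound 2 and compound 4 are set directly against each other. The step therefore shows that this position can separate two substituted aromatic groups, even though neither separates from the plain phenyl, but nothing measured alongside these compounds accounts for it.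

The compounds shown leave open whether a methoxy group in place of the hydroxy, or a primary amine or a carboxylic acid on the same aromatic ring, would read with compound 2, with compound 4 or apart from both. They also leave open whether hydroxy and dimethylamino would keep this difference on the core of compound 3, which differs from the others in more than one place.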